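Removing cyano from compound 2

The compounds below may be only part of what the source reports. "The series", "measured", "known", "first", "only" and "open" are said of these compounds alone.

In a functional assay on MCF7 cells (Homo sapiens) for antiproliferative activity, read by CellTiter-Glo, with a stated time of 5 days (on this read-out lower numbers stand for stronger inhibition and higher numbers for weaker inhibition), compound 1 `CC1=C(c2cccc(O)c2)C(c2ccc(OC[C@H](C)N3CCCCC3)cc2)Oc2ccc(O)cc21` gives 0.1 nM, compound 3 `CC1=C(c2cccc(O)c2)C(c2ccc(OC[C@@H](C)N3CC[C@H](C)C3)cc2)Oc2ccc(O)cc21` gives 0.2 nM and compound 2 `CC1=C(c2ccc(C#N)cc2)C(c2ccc(OC[C@H](C)N3CC[C@@H](C)C3)cc2)Oc2ccc(O)cc21` gives 10 nM, the highest of the three numbers and beyond the scatter from both others. Compound 4 `CC1=C(c2ccccc2)C(c2ccc(OC[C@H](C)N3CC[C@@H](C)C3)cc2)Oc2ccc(O)cc21` differs from compound 2 by hydrogen in place of cyano on an aromatic carbon, para to a large group. For the measured compounds named here, the only measured step, a 2.0-fold higher number from compound 1 to compound 3 (0.30 log units; within the scatter), exchanges one non-aromatic ring for another and removes no cyano. Compounds 1 and 3 lack cyano but differ from compound 2 elsewhere too, so they offer only weak guidance. A moderate move to a lower number is expected in this assay, with the step estimated as a 3.3-fold lower number from compound 2 to compound 4 (0.52 log units; beyond the scatter). For compound 4 the estimate is 3 nM, with an expected range of 0.5 nM to 15 nM.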

Compound 4, half-maximal inhibitory concentration: 0.4 nM
For compound 4 the middle estimate is 7.5-fold (0.88 log units) above the measured one; the measured number lies below the stated range.
By their numbers in this assay, from the lowest: compounds 1, 3 and 4 (each within the scatter of the next, the first and the last beyond it); then compound 2.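

In this assay the nitrile para to a large group proves decisive: a 25-fold lower number from compound 2 to compound 4 (1.40 log units; beyond the scatter) and lies beyond the scatter, so replacing cyano with hydrogen alone accounts for this large gap. For the compounds shown here, the only earlier step, a 2.0-fold higher number from compound 1 to compound 3 (0.30 log units; within the scatter) and within the scatter, concerned the non-aromatic amine ring and did not touch this aromatic carbon. Nothing at hand explains the size of the step.

On these data alone, whether fluorine, methoxy or an amide at this place would track compound 4 or compound 2 remains open. So does whether removing cyano gives a step of similar size with a different amine ring.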